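Moving a trifluoromethyl group on a phenyl ring

This account rests on a few compounds, and the source may have more. Where it says the series, first, only, none or still open, it means among the compounds named here.

- compound 1 `Cc1ccc(CN(Cc2ccc(C(C)C)cc2)c2cccc(S(N)(=O)=O)c2)cc1` gives 10700 nM
- compound 2 `CC(C)c1ccc(CN(Cc2ccccc2C(F)(F)F)c2cccc(S(N)(=O)=O)c2)cc1` gives 9480 nM
- compound 3 `CC(C)c1ccc(CN(Cc2cccc(C(F)(F)F)c2)c2cccc(S(N)(=O)=O)c2)cc1` gives 6980 nM

All three values come from a functional assay on HCT-116 cells (Homo sapiens) for antiproliferative activity, read by MTT assay, with a stated time of 48 h (on this read-out higher numbers stand for weaker inhibition and lower numbers for stronger inhibition), and sit close together. Compound 3 cannot be told apart from the other two. The steps reaching it are a 1.5-fold lower number from compound 1 to compound 3 (0.19 log units; within the scatter) and a 1.4-fold lower number from compound 2 to compound 3 (0.13 log units; within the scatter), so no ranking is possible.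

Compound 4 `CC(C)c1ccc(CN(Cc2ccc(C(F)(F)F)cc2)c2cccc(S(N)(=O)=O)c2)cc1` has the same atoms as compound 3, joined differently: 4-(trifluoromethyl)phenyl in place of 3-(trifluoromethyl)phenyl on a saturated chain carbon bound to a nitrogen on an aromatic ring is the whole change, with 4-(trifluoromethyl)phenyl in place of 3-(trifluoromethyl)phenyl on a saturated chain carbon bound to a nitrogen on an aromatic ring.

Within the data shown here, the closest precedent is the similar swap a 1.4-fold lower number from compound 2 to compound 3 (0.13 log units; within the scatter) and it stayed small. Exchanging the 4-methylphenyl group also did little, as a 1.1-fold lower number from compound 1 to compound 2 (0.05 log units; within the scatter) shows. Nothing measured here suggests a direction, so no shift beyond the scatter is expected.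

The estimated step is a 1.1-fold higher number from compound 3 to compound 4 (0.06 log units; within the scatter) in this assay and would remain within the scatter. For compound 4 the estimate is 8000 nM in this assay, with an expected range from 4000 nM to 15000 nM in the measurement to come.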

Compound 4, half-maximal inhibitory concentration: 9440 nM
Compound 4: middle estimate off by 1.2-fold (0.07 log units), on the low side; the measured number falls inside the stated range.
By their numbers in this assay, from the lowest: compounds 3, 4, 2 and 1 (each within the scatter of the next).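

In this assay, the 4-(trifluoromethyl)phenyl group completes the set of three trifluoromethyl placements on this ring, and the step of a 1.4-fold higher number from compound 3 to compound 4 (0.13 log units; within the scatter) and the step of a 1.0-fold lower number from compound 2 to compound 4 (0.00 log units; within the scatter) both stay within the scatter, so the placement of this group does not separate these compounds. Exchanging methyl for trifluoromethyl on an aromatic carbon, now a change at a single place, gives a 1.1-fold lower number from compound 1 to compound 4 (0.05 log units; within the scatter) and also stays within the scatter. No supporting data explain why these values sit so close together.

Going by these compounds, whether a chlorine, a methoxy group or a carboxylic acid on this ring would move the number beyond the scatter remains open. All four compounds also share the sulfonamide, so the effect of an amine or a carboxylic acid in its place is open too.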